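The source may report more compounds than this note shows. Statements on the series, on what has been measured and on what is new or still open speak of the compounds shown alone.

Measured so far in a functional assay on HepG2 cells (Homo sapiens) for inhibition, read by MTT assay, with a stated time of 48 h; a lower number here means a stronger inhibitor, a higher number a weaker inhibitor:

compound 1 `Cc1ccc(/C=C2\SC(=O)N(CCNC(=O)Nc3c(C)n(C)n(-c4ccccc4)c3=O)C2=O)cc1` gives 25700 nM
compound 2 `COc1ccc(/C=C2\SC(=O)N(CCNC(=O)Nc3c(C)n(C)n(-c4ccccc4)c3=O)C2=O)cc1` gives 8370 nM
compound 3 `Cc1c(NC(=O)NCCN2C(=O)S/C(=C\c3ccc([N+](=O)[O-])cc3)C2=O)c(=O)n(-c2ccccc2)n1C` gives 14000 nM

Compound 3 cannot be told apart from the other two, as the steps of a 1.8-fold lower number from compound 1 to compound 3 (0.26 log units; within the scatter) and a 1.7-fold higher number from compound 2 to compound 3 (0.22 log units; within the scatter) both show on their own. Compound 4 `COc1cc(/C=C2\SC(=O)N(CCNC(=O)Nc3c(C)n(C)n(-c4ccccc4)c3=O)C2=O)cc(OC)c1OC` has 3,4,5-trimethoxyphenyl in place of 4-nitrophenyl on a double-bonded chain carbon bound to a double-bonded ring carbon. The change in full is 3,4,5-trimethoxyphenyl in place of 4-nitrophenyl on a double-bonded chain carbon bound to a double-bonded ring carbon and it is the step followed here.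

The closest guide is the swap between methoxy and nitro, seen in a 1.7-fold higher number from compound 2 to compound 3 (0.22 log units; within the scatter) and small. Among the compounds with values here, the only step past the scatter is a 3.1-fold lower number from compound 1 to compound 2 (0.49 log units; beyond the scatter) with methoxy in place of methyl, and it is modest. Within the data shown here, no measured compound carries the 3,4,5-trimethoxyphenyl group, so the guide is only partial. In this assay no shift beyond the scatter is therefore expected. The expected step is a 1.3-fold lower number from compound 3 to compound 4 (0.10 log units; within the scatter) and nothing larger. For compound 4 the estimated value is 11000 nM with an expected range from 4500 nM to 27000 nM in this read-out.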

Compound 4, half-maximal inhibitory concentration: 10800 nM
Compound 4: middle estimate off by 1.0-fold (0.01 log units), on the high side; the range from low to high includes it.
By their numbers in this assay, from the lowest: compounds 2, 4, 3 and 1 (each within the scatter of the next, the first and the last beyond it).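

In this assay the 3,4,5-trimethoxyphenyl group on a double-bonded chain carbon bound to a double-bonded ring carbon is accepted without a clear change: a 1.3-fold lower number from compound 3 to compound 4 (0.11 log units; within the scatter) and a 1.3-fold higher number from compound 2 to compound 4 (0.11 log units; within the scatter) are both within the scatter, so three methoxy groups on the ring cannot be told apart from one methoxy group or from a nitro group. The only clear difference is a 2.4-fold lower number from compound 1 to compound 4 (0.38 log units; beyond the scatter), which is modest and matches the gap already seen between the 4-methylphenyl compound and the 4-methoxyphenyl compound. No measurement here explains these results.

From the compounds shown here alone, all four compounds carry a substituted phenyl ring at this position, so it remains open whether a dimethylamino group or a carboxylic acid on that ring, or a pyridine ring in its place, would shift the number further. Going by these compounds, the ethylene chain and the rest of the shared core are also the same throughout, so their contribution is unknown.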